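A Larger Amide Substituent on the Shared Core

This account rests on a few compounds, and the source may have more. Where it says the series, first, only, none or still open, it means among the compounds named here.

Compound 2 `CC(C(=O)N1CCC2(CC1)CC2)N1CCN(S(=O)(=O)c2ccc(C(C)(C)C)cc2)CC1` shares its core with compound 1 `CC(C(=O)N1CCCCCC1)N1CCN(S(=O)(=O)c2ccc(C(C)(C)C)cc2)CC1` and differs from it only at the carbonyl carbon. In an ADME assay on HepG2 cells (Homo sapiens) for inhibition, with a stated time of 48 h (on this read-out higher numbers stand for an effect only at larger amounts of compound and lower numbers for an effect already at smaller amounts), compound 1 reaches only the limit of the assay, > 40000 nM. In this assay compound 2 likewise reaches only the limit, > 40000 nM. The step that the two limits leave unreadable from compound 1 to compound 2 cannot be sized because of the limit of > 40000 nM in this assay, at which 2 of the 2 values shown sit. Compound 2 therefore stands at the limit, and no number places it.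

Compound 3 `CC(C(=O)N1CCCc2ccccc21)N1CCN(S(=O)(=O)c2ccc(C(C)(C)C)cc2)CC1` differs from compound 2 in a group of 10 heavy atoms (9 carbon, 1 nitrogen; one six-membered non-aromatic ring with 1 hetero atom, one six-membered aromatic ring of carbon only) in place of a group of 8 heavy atoms (7 carbon, 1 nitrogen; one three-membered non-aromatic ring of carbon only, one six-membered non-aromatic ring with 1 hetero atom), on a carbonyl carbon. Going by the values given here, the only measured step touching this position is unreadable, so nothing measured points to a direction or a size for this exchange beyond the scatter. For compound 3 in this assay a value of 60000 nM is expected, most probably again reported as a limit, with a range from 30000 nM to 200000 nM. The expected step that the limit leaves unreadable from compound 2 to compound 3 is accordingly no change that the assay would resolve.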

Compound 3, half-maximal effective concentration: > 40000 nM
Compound 3: only a limit was reported; the forecaster's own chance of this, stated with the estimate: 80%; the middle value lies beyond the limit too.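

In this assay compound 3 gives > 40000 nM as a limit of the assay. Going by these compounds alone, no step among compound 1, compound 2 and compound 3 can therefore be read: (the limit of > 40000 nM in this assay, at which 3 of the 3 values shown sit). The compounds shown leave open how far apart these three lie in this assay and whether any substituent on this carbonyl carbon gives a readable value.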